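The source may report more compounds than this note shows. Statements on the series, on what has been measured and on what is new or still open speak of the compounds shown alone.

Working notes on the series

Compound 1 `CCCCCCCCCCn1cc(-c2nc3ccccc3cc2CCCC)nn1` and compound 2 `CCCCCCCCCCn1cc(-c2nc3ccccc3cc2CCCCC)nn1` share one core; compound 3 `CCc1cc2ccccc2nc1-c1cn(CCC(F)(F)C(F)(F)C(F)(F)C(F)(F)C(F)(F)C(F)(F)C(F)(F)C(F)(F)F)nn1` and compound 4 `CCCc1cc2ccccc2nc1-c1cn(CCC(F)(F)C(F)(F)C(F)(F)C(F)(F)C(F)(F)C(F)(F)C(F)(F)C(F)(F)F)nn1` share another. The difference between the two cores is not broken down here.

In a functional assay on THP-1 cells (Homo sapiens) for cytotoxicity, read by MTT assay, with a stated time of 24 h (a higher number here means a weaker inhibitor, a lower number a stronger inhibitor), compound 1 gives only a limit of the assay, > 100 ug/mL. Compound 2 gives a number in this assay, 88 ug/mL. The step between them is methyl in place of hydrogen on a saturated chain carbon, four bonds along the chain from an aromatic carbon, and it reads an at least 1.1-fold lower number from compound 1 to compound 2 (0.05 log units; that floor lies within the scatter). Compound 3 also gives only a limit in this assay, > 100 ug/mL, as noted in the limit of > 100 ug/mL in this assay, at which 2 of the 3 values shown sit.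

Compound 4 carries the same kind of change relative to compound 3, (methyl in place of hydrogen on a saturated chain carbon, two bonds along the chain from an aromatic carbon); the two changes differ in their place, four bonds along the chain from an aromatic carbon in the first pair and two bonds along the chain from an aromatic carbon in the second.

For compound 4 a small downward step is expected from compound 3 in this assay, an at least 1.0-fold lower number from compound 3 to compound 4 (0.02 log units; that floor lies within the scatter), resting on the step seen in this assay from compound 1 to compound 2, an at least 1.1-fold lower number from compound 1 to compound 2 (0.05 log units; that floor lies within the scatter), which starts from a limit and lands at a number nearby. Since compound 3 sits at a limit, it is quite possible that compound 4 again reports only a limit. The estimate for compound 4 in this assay is 95 ug/mL, with a range from 55 ug/mL to 200 ug/mL.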

Compound 4, half-maximal inhibitory concentration: > 100 ug/mL
Compound 4 gave a limit, no number (the forecaster's own chance of this, stated with the estimate: 55%); middle value at least 1.0-fold (0.02 log units) away from the limit.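

Compound 3 and compound 4 each report only a limit in this assay, so the step between them cannot be read and no new step comes from this pair: the limit of > 100 ug/mL in this assay, at which 3 of the 4 values shown sit.

The compounds shown leave open whether methyl in place of hydrogen, on a saturated chain carbon, two bonds along the chain from an aromatic carbon, changes the reading in this assay at all on the core shared by compound 3 and compound 4.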